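Compound 4: another aryl swap at the assay limit

A few compounds are considered here, and "the series" means these few. Any claim that something is new, unique, unknown or untested is made for them only; others in the source may bear on it.

Measured in a functional assay on U-87MG ATCC cells for antiproliferative activity against U-87 MG (Homo sapiens), read by spectrophotometry, with a stated time of 2 days; a lower number here means a stronger inhibitor of growth, a higher number a weaker inhibitor of growth:
Compound 1 `COc1ccc(C(F)(F)F)cc1Nc1ncc(C(F)(F)F)c(N2Cc3cccc(N(C)S(C)(=O)=O)c3C2)n1` gives > 30000 nM (a limit)
Compound 2 `Cc1ccc(Nc2ncc(C(F)(F)F)c(N3Cc4cccc(N(C)S(C)(=O)=O)c4C3)n2)c(Cl)c1` gives > 30000 nM (a limit)
Compound 3 `CN(c1cccc2c1CN(c1nc(Nc3ccc(C(F)(F)F)cc3)ncc1C(F)(F)F)C2)S(C)(=O)=O` gives > 30000 nM (a limit)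

Compound 3 has no number in this assay, only the limit > 30000 nM (and it is not alone there). Within the data shown here, the whole series sits at one point, the limit of > 30000 nM in this assay, at which 3 of the 3 values shown sit (no compound has yet given a number).

Among the measured compounds shown here, compound 4 `Cc1cc(C)cc(Nc2ncc(C(F)(F)F)c(N3Cc4cccc(N(C)S(C)(=O)=O)c4C3)n2)c1` keeps the shared core and changes only the group on the nitrogen, 3,5-dimethylphenyl in place of 4-(trifluoromethyl)phenyl on a nitrogen on an aromatic ring (the sole difference from compound 3).

Three measured steps change the group at this same place: a step that the two limits leave unreadable from compound 1 to compound 2, a step that the two limits leave unreadable from compound 1 to compound 3 and a step that the two limits leave unreadable from compound 2 to compound 3 (none with a readable size). They therefore give no direction for the new change, and no size can be taken from them.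

The expectation rests on compound 3, with its limit of > 30000 nM (a limit only).

The expected outcome is a number no higher from compound 3 to compound 4 (the limit leaves the size open) (with no direction supported by the data).

For compound 4 the estimated value is 30000 nM (expected range 12000 nM to 60000 nM), and the assay will most likely report only a limit again.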

Compound 4, concentration for 50% growth inhibition: > 30000 nM
Compound 4 was reported as a limit (the forecaster's own chance of this, stated with the estimate: 85%); the middle value lies on the limit itself.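

In this assay compound 4 gives > 30000 nM, which is a limit. The steps from compound 1, compound 2 and compound 3 to compound 4 therefore cannot be read: the limit of > 30000 nM in this assay, at which 4 of the 4 values shown sit.

The compounds shown leave open whether any group on the nitrogen gives a readable number in this assay.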